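The source may hold more compounds than are shown below. What is called first, only, known or untested is meant among the compounds shown, and "the series" means these compounds.

Three compounds have been measured in a functional assay, read by spectrophotometry, with a stated time of 15 min; on this read-out lower numbers stand for stronger inhibition and higher numbers for weaker inhibition:
compound 1 `Cc1nc2c3ccccc3ccc2c2nc3c(ccc4ccccc43)c(-c3cccc([N+](=O)[O-])c3)c12`, 54.2 ug/mL;
compound 2 `Cc1nc2c3ccccc3ccc2c2nc3c(ccc4ccccc43)c(-c3cccnc3)c12`, 63.6 ug/mL;
compound 3 `Cc1nc2c3ccccc3ccc2c2nc3c(ccc4ccccc43)c(-c3cc([N+](=O)[O-])ccc3N)c12`, 43.3 ug/mL.

Compound 3 sits within the scatter of both others: a 1.3-fold lower number from compound 1 to compound 3 (0.10 log units; within the scatter) and a 1.5-fold lower number from compound 2 to compound 3 (0.17 log units; within the scatter), so no order among the three can be claimed. Compound 4 `Cc1ccc(-c2c3ccc4ccccc4c3nc3c2c(C)nc2c4ccccc4ccc32)cc1` is not yet measured; it differs from compound 3 in one place: 4-methylphenyl in place of 2-amino-5-nitrophenyl on an aromatic carbon. The nearest precedents are the two earlier swaps of the group at this position, a 1.2-fold higher number from compound 1 to compound 2 (0.07 log units; within the scatter) and a 1.5-fold lower number from compound 2 to compound 3 (0.17 log units; within the scatter), together with the addition of a group, a 1.3-fold lower number from compound 1 to compound 3 (0.10 log units; within the scatter), all within the scatter. A step of similar size, not beyond the scatter, is therefore expected in this assay, a 1.2-fold higher number from compound 3 to compound 4 (0.06 log units; within the scatter). Compound 4 is estimated at 50 ug/mL, in a range from 25 ug/mL to 100 ug/mL.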

Compound 4, half-maximal inhibitory concentration: 68.7 ug/mL
Compound 4: the middle estimate sits 1.4-fold (0.14 log units) below what was measured; measured number inside the range.
By their numbers in this assay, from the lowest: compounds 3, 1, 2 and 4 (each within the scatter of the next).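

In this assay, the entering 4-methylphenyl has only carbon atoms and 0 hydrogen-bond donors, yet compound 4 stays within the scatter of all three earlier compounds (a 1.6-fold higher number from compound 3 to compound 4 (0.20 log units; within the scatter)), (a 1.1-fold higher number from compound 2 to compound 4 (0.03 log units; within the scatter)) and (a 1.3-fold higher number from compound 1 to compound 4 (0.10 log units; within the scatter)). At this position, opposite the ring nitrogen, an aromatic ring carrying neither amino nor nitro thus gives no readable difference from one carrying them. Nothing available explains this result. Still open, as far as these compounds go, is whether a phenyl bearing a carboxylic acid, or a simple ethyl chain in place of the aromatic ring, would give a step beyond the scatter.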